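Dihydropyrimidinone series: ester to pyridinyl amide, cytotoxicity

A few compounds are considered here, and "the series" means these few. Any claim that something is new, unique, unknown or untested is made for them only; others in the source may bear on it.

Within the data shown here, compound 3 `CC1=C(C(=O)OC(C)(C)C)C(c2cccs2)NC(=O)N1`, compound 1 `CC1=C(C(=O)Nc2ccccc2Cl)C(c2ccccc2Cl)NC(=O)N1` and compound 2 `CC1=C(C(=O)Nc2ccccc2Cl)C(c2ccc([N+](=O)[O-])cc2)NC(=O)N1` are the three members so far tested in an ADME assay on Vero cells (Chlorocebus sabaeus) for cytotoxicity, read by XTT assay, with a stated time of 72 h; a lower number here means that less compound is tolerated, a higher number that more compound is tolerated. Compound 1 is reported as "non-toxic" (no number reported) in this assay, and compound 2 likewise as "non-toxic" (no number reported). For compound 3 this assay gives only a limit, > 100000 nM, not a number. Where compound 3 stands is told by the limit of > 100000 nM in this assay, at which 1 of the 3 values shown sits; the other two entries carry no number at all, so no ordering among the three can be read.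

Compound 4 `CC1=C(C(=O)Nc2ccccn2)C(c2cccs2)NC(=O)N1` has not been measured. It differs from compound 3 by (pyridin-2-yl)amino in place of tert-butoxy on a carbonyl carbon. Among the measured compounds shown here, no step between two measured compounds is available, so the size of this change cannot be drawn from the series itself. Compound 1 with "non-toxic" (no number reported) and compound 2 with "non-toxic" (no number reported) show that a change at the carbonyl carbon has so far left the compounds without toxicity. The expectation for the step is therefore none beyond the scatter, a number no higher from compound 3 to compound 4 (the limit leaves the size open). Compound 4 is estimated at 100000 nM in this assay, with a range from 30000 nM to 300000 nM, most likely again reported only as a limit.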

Compound 4, half-maximal cytotoxic concentration: > 100000 nM
Compound 4: only a limit was reported (the forecaster's own chance of this, stated with the estimate: 80%); the middle value sits exactly at the limit.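

Among these compounds, compound 3 and compound 4 both carry only limits in this assay, and no step between them can be read. The compounds shown leave open at what concentration, if any, cytotoxicity appears, and whether (pyridin-2-yl)amino in place of tert-butoxy changes it.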